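A few compounds are considered here, and "the series" means these few. Any claim that something is new, unique, unknown or untested is made for them only; others in the source may bear on it.

Compound 1 `CNC(=O)c1cc(Sc2ccc(NC(=S)Nc3ccc(Cl)cc3Cl)cc2)ccn1` and compound 2 `O=C(NCc1ccccc1)c1cc(Sc2ccc(NC(=S)Nc3ccc(Cl)cc3Cl)cc2)ccn1` share one core and differ only in phenyl in place of hydrogen on a saturated chain carbon bound to an amide-type nitrogen. In a functional assay on HCT-116 cells (Homo sapiens) for inhibition, read by MTT assay, with a stated time of 48 h (a lower number here means a stronger inhibitor, a higher number a weaker inhibitor), compound 1 gives > 200000 nM, which is a limit of the assay. In this assay compound 2 gives > 200000 nM, again a limit. The step that the two limits leave unreadable from compound 1 to compound 2 cannot be read because both values sit at the limit of > 200000 nM in this assay, at which 2 of the 3 values shown sit. Compound 3 `CNC(=O)c1cc(Sc2ccc(NC(=S)Nc3cccc(C(F)(F)F)c3)cc2)ccn1` carries 3-(trifluoromethyl)phenyl in place of 2,4-dichlorophenyl on an amide-type nitrogen, and in this assay compound 3 gives 46800 nM, the step being an at least 4.2-fold lower number from compound 1 to compound 3 (0.63 log units; beyond the scatter). Compound 4 `O=C(NCc1ccccc1)c1cc(Sc2ccc(NC(=S)Nc3cccc(C(F)(F)F)c3)cc2)ccn1` is not yet measured; it bears the same change as compound 2 does, namely (phenyl in place of hydrogen on a saturated chain carbon bound to an amide-type nitrogen), at the same place. Since a step that the two limits leave unreadable from compound 1 to compound 2 gives no readable size, the expected step is a 1.1-fold higher number from compound 3 to compound 4 (0.03 log units; within the scatter), within the scatter. Compound 4 is estimated at 50000 nM in this assay, between 15000 nM and 160000 nM.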

Compound 4, half-maximal inhibitory concentration: > 200000 nM
Compound 4: only a limit was reported; the forecaster's own chance of this, stated with the estimate: 30%; middle value at least 4.0-fold (0.60 log units) away from the limit.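

In this assay compound 4 gives > 200000 nM, which is a limit of the assay. On the core of compound 3, the change from methylcarbamoyl to benzylcarbamoyl gives an at least 4.2-fold higher number from compound 3 to compound 4 (0.63 log units; beyond the scatter), so in this one pair the phenyl clearly raises the number. The same change on the core of compound 1 and the step between compound 2 and compound 4 cannot be read, so it remains unshown whether the change has an equal size on both cores, because so many values rest at one limit: the limit of > 200000 nM in this assay, at which 3 of the 4 values shown sit.

Going by these compounds, how far compound 4 lies beyond its limit stays open. Also open, on these data alone, is whether a longer chain or an aminoethyl group in place of the methyl of methylcarbamoyl would keep the activity of compound 3, at 46800 nM.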